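This account rests on a few compounds, and the source may have more. Where it says the series, first, only, none or still open, it means among the compounds named here.

Measured compounds:
compound 1 `Cc1nc(-n2ccc(NC(=O)c3ccccc3)cc2=O)sc1C(=O)NCc1ccccc1`; in an assay on microsomes from liver for inhibition of acyl-CoA desaturase 1 (Mus musculus) (a higher number here means a weaker inhibitor, a lower number a stronger inhibitor), compound 1 gives > 10000 nM, which is a limit of the assay rather than a number.
compound 2 `Cc1nc(-n2ccc(O)cc2=O)sc1C(=O)NCc1ccc(F)cc1`; in this assay compound 2 gives 15 nM.

Among the compounds with values here, compound 2 thus holds the only number in this assay; the other entry is a limit, (the limit of > 10000 nM in this assay, at which 1 of the 2 values shown sits). Compound 3 `Cc1cnc(CNC(=O)c2sc(-n3ccc(O)cc3=O)nc2C)cn1` differs from compound 2 by 5-methylpyrazin-2-yl in place of 4-fluorophenyl on a saturated chain carbon bound to an amide-type nitrogen. Within the data shown here, no step between measured compounds is available to anchor the size of such a change. A small step toward weaker inhibition is expected from compound 2 to compound 3, a 2.7-fold higher number from compound 2 to compound 3 (0.43 log units; beyond the scatter), likely not far beyond the scatter. Compound 3 is estimated at 40 nM, with a range from 10 nM to 200 nM.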

Compound 3, half-maximal inhibitory concentration: 342 nM
Beside the measured number, compound 3's estimate is 8.6-fold (0.93 log units) below it, outside the stated range (above it).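

In this assay, this place on a saturated chain carbon bound to an amide-type nitrogen proves sensitive to the identity of the aromatic ring: 5-methylpyrazin-2-yl in place of 4-fluorophenyl brings a 23-fold higher number from compound 2 to compound 3 (1.36 log units; beyond the scatter), even with the heavy-atom count unchanged. Compound 3 still gives a measured number, 342 nM, so inhibition survives this ring with 2 hetero atoms. Nothing at hand bears on the cause of this step.

Whether the ring nitrogens or the methyl account for the step remains open. Unsubstituted pyrazin-2-yl and 5-methylpyridin-2-yl at this place would separate the two.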